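The source may hold more compounds than are shown below. What is called first, only, known or untested is meant among the compounds shown, and "the series" means these compounds.

Compound 3 `Cc1cc(C)c(-c2cccnc2)cc1NC(=O)c1ccc(OCc2ccccn2)cc1` sits at the upper limit of a physicochemical assay for lipophilicity; on this read-out lower numbers stand for lower lipophilicity and higher numbers for higher lipophilicity: in this assay compound 3 gives > 3, which is a limit and not a number. Among the measured compounds shown here, compound 1 `Cc1ncc(-c2cc(NC(=O)c3ccc(OCc4ccccn4)cc3)c(C)cc2C)[nH]1` is the one member of the set with a read number, since in this assay compound 1 gives 2.8. Compound 2 `Cc1cc(C)c(-c2c(C)nn(C)c2C)cc1NC(=O)c1ccc(OCc2ccccn2)cc1` also returns a limit, as in this assay compound 2 gives > 3. The measured steps run upward: a number at least 0.20 log units higher from compound 1 to compound 2 (that floor lies within the scatter) and a number at least 0.20 log units higher from compound 1 to compound 3 (that floor lies within the scatter), while a step that the two limits leave unreadable from compound 2 to compound 3, because of the limit of > 3 in this assay, at which 2 of the 3 values shown sit. Compound 4 `Cc1cc(C)c(-c2ccc(N)nn2)cc1NC(=O)c1ccc(OCc2ccccn2)cc1` differs from compound 3 in a single place: 6-aminopyridazin-3-yl in place of pyridin-3-yl on an aromatic carbon. For the measured compounds named here, none of the measured steps exchanges a pyridin-3-yl for a 6-aminopyridazin-3-yl, so they bear on this change only by showing how far the set reaches in this assay. Compound 4 is therefore expected to land below the limit, with an estimated step of a number at least 0.80 log units lower from compound 3 to compound 4 (beyond the scatter). For compound 4 the estimate in this assay is 2.2, between 1.5 and 2.9.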

Compound 4, distribution coefficient: 2.6
Compound 4: the middle estimate sits 0.40 log units below what was measured; the measured number falls inside the stated range.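

Compound 4 shows that a group at this aromatic carbon can bring the read-out back from the limit. In this assay, 6-aminopyridazin-3-yl in place of pyridin-3-yl gives a number at least 0.40 log units lower from compound 3 to compound 4 (beyond the scatter), and in place of 1,3,5-trimethyl-1H-pyrazol-4-yl it gives a number at least 0.40 log units lower from compound 2 to compound 4 (beyond the scatter). In place of 2-methyl-1H-imidazol-5-yl it gives a number 0.20 log units lower from compound 1 to compound 4 (within the scatter), so these two groups are not separated at this position, and the full size of the other two steps cannot be read: the limit of > 3 in this assay, at which 2 of the 4 values shown sit.

The compounds shown leave open how much of the change belongs to the amine and how much to the extra ring nitrogen. A plain pyridazin-3-yl or a 6-aminopyridin-3-yl at this position would separate the two, and an N-methylamine or an acetamide on the same ring would test the amine itself.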